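This account rests on a few compounds, and the source may have more. Where it says the series, first, only, none or still open, it means among the compounds named here.

Compound 2 `Cc1n[nH]c(C)c1-c1cncc(-c2ccc(C(N)=O)c(OC(C)C)c2)c1` is the strongest inhibitor among the three compounds measured in an assay on cells for inhibition of MAP kinase-interacting serine/threonine-protein kinase 1 (Homo sapiens), read by mobility shift assay, with stated times of 10 min and 60 min, in the presence of a further agent that is not named here (on this read-out higher numbers stand for weaker inhibition and lower numbers for stronger inhibition), where compound 2 gives 33 nM. Its nearest neighbour is compound 1 `CC(C)Oc1cc(-c2cncc(-c3cnn(C)c3)c2)ccc1C(N)=O`, which in this assay gives 400 nM, and the furthest is compound 3 `NC(=O)c1ccc(-c2cccnc2)cc1O`, which in this assay gives 4300 nM; both gaps lie beyond the scatter. Among the measured compounds shown here, the only measured step that alters a single place is a 12-fold lower number from compound 1 to compound 2 (1.08 log units; beyond the scatter), the exchange of 1-methyl-1H-pyrazol-4-yl for 3,5-dimethyl-1H-pyrazol-4-yl on an aromatic carbon.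

Compound 4 `CC(C)Oc1cc(-c2cncc(-c3cnn(C(C)C)c3)c2)ccc1C(N)=O` has not yet been measured. It differs from compound 2 by 1-isopropyl-1H-pyrazol-4-yl in place of 3,5-dimethyl-1H-pyrazol-4-yl on an aromatic carbon, so the 3,5-dimethyl-1H-pyrazol-4-yl that set compound 2 apart from compound 1 is again exchanged for a pyrazole with an alkyl group on nitrogen, now 1-isopropyl-1H-pyrazol-4-yl instead of 1-methyl-1H-pyrazol-4-yl. For the measured compounds named here, the step from compound 1 to compound 2 is the one measured step that bears on this change, and it was large; read in reverse it points to a return toward the number of compound 1. Going by the values given here, no measured pair shows how 1-isopropyl-1H-pyrazol-4-yl compares with 1-methyl-1H-pyrazol-4-yl, so the range is kept wide. Compound 4 is therefore expected to give 300 nM in this assay, with a likely range from 100 nM to 1000 nM, an expected step of a 9.1-fold higher number from compound 2 to compound 4 (0.96 log units; beyond the scatter).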

Compound 4, half-maximal inhibitory concentration: 85 nM
Compound 4: the middle estimate sits 3.5-fold (0.55 log units) above what was measured, outside the stated range (below it).
By their numbers in this assay, from the lowest: compound 2; then compound 4; then compound 1; then compound 3.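

In this assay, isopropyl in place of methyl on an aromatic nitrogen gives a 4.7-fold lower number from compound 1 to compound 4 (0.67 log units; beyond the scatter), the first measured sign that the alkyl group on the pyrazole nitrogen alone can move the number at this position, on an aromatic carbon of a six-membered aromatic ring with 1 nitrogen. Exchanging 3,5-dimethyl-1H-pyrazol-4-yl for 1-isopropyl-1H-pyrazol-4-yl gives a 2.6-fold higher number from compound 2 to compound 4 (0.41 log units; beyond the scatter), so a modest part of the difference remains, while a group counted with 0 hydrogen-bond donors still recovers part of the change seen in a 12-fold lower number from compound 1 to compound 2 (1.08 log units; beyond the scatter). The hydrogen-bond donor of 3,5-dimethyl-1H-pyrazol-4-yl is therefore not the only route to a lower number among these compounds, although compound 2 still gives the lowest number of the set. Nothing shown here gives a reason for these differences.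

On these data alone, it remains open whether an ethyl group, a cyclopropyl group or a longer chain on the same nitrogen would lower the number further, or whether an amine at the end of such a chain would be tolerated. Also open, as far as these compounds go, is how a pyrazole carrying both the isopropyl group and the two methyl groups would read.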